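Cytotoxicity notes: acetyl replaced by a bicyclic group

The compounds below may be only part of what the source reports. "The series", "measured", "known", "first", "only" and "open" are said of these compounds alone.

Compound 1 `CC(=O)c1ccc(NCc2cncn2Cc2ccc(-c3ccccc3)cc2)cc1-c1ccccc1` is tested in a toxicity assay on NIH3T3 cells (Mus musculus) for cytotoxicity, read by resazurin assay; on this read-out lower numbers stand for an effect already at smaller amounts and higher numbers for an effect only at larger amounts of compound. In this assay compound 1 gives > 10000 nM, which is a limit of the assay and not a number (the limit of > 10000 nM in this assay, at which 1 of the 3 values shown sits). Compound 2 `CC(C)c1ccc(Cn2cncc2CNc2ccc(-c3nc4ccccc4s3)c(-c3ccccc3)c2)cc1` carries a related core; in this assay compound 2 gives > 1000 nM, again a limit of the assay rather than a number (the limit of > 1000 nM in this assay, at which 1 of the 3 values shown sits). Compound 3 `COC(=O)c1ccc(NCc2cncn2Cc2ccccc2F)cc1-c1ccccc1` has no result in this assay, "not determined" (no result reported). Among the measured compounds shown here, no step between measured compounds can be computed, so compound 1 stands only as a limit among limits.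

Compound 4 `c1ccc(-c2ccc(Cn3cncc3CNc3ccc(-c4noc5ccccc45)c(-c4ccccc4)c3)cc2)cc1` is not yet measured. The change from compound 1 is a group of 9 heavy atoms (7 carbon, 1 nitrogen, 1 oxygen; one five-membered aromatic ring with 2 hetero atoms, one six-membered aromatic ring of carbon only) in place of a group of 3 heavy atoms (2 carbon, 1 oxygen; no ring), on an aromatic carbon, placed ortho to a phenyl group and para to a large group. With only limits shown and no measured step, no movement beyond the scatter in this assay is expected in either direction, and a further limit is the likely outcome. For compound 4 the expected value in this assay is 10000 nM, with a range from 2000 nM to 50000 nM. This estimate corresponds to a step of a number no higher from compound 1 to compound 4 (the limit leaves the size open), expected to stay within the scatter.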

Compound 4, half-maximal effective concentration: > 10000 nM
Compound 4: no number, only a limit; the forecaster's own chance of this, stated with the estimate: 80%; the middle value sits exactly at the limit.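

In this assay, among the compounds shown here, compound 1 and compound 4 each stand only as a limit of the assay, so no step between them can be read. The compounds shown leave open whether exchanging the acetyl for the bicyclic group changes cytotoxicity at all.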